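The source may hold more compounds than are shown below. What is called first, only, known or untested is meant among the compounds shown, and "the series" means these compounds.

Working notes on the series, read in an ADME assay on L02 cells (Homo sapiens) for antiproliferative activity, read by MTT assay, with a stated time of 48 h; a lower number here means a stronger inhibitor, a higher number a weaker inhibitor. Compound 1 (`CCn1c(C(=O)NCCCN(C)C)ccc1C(CC)(CC)c1ccc(OCCC(O)(CC)CC)c(C)c1`) gives 2420 nM. Compound 2 (`CCN(CC)CCNC(=O)c1ccc(C(CC)(CC)c2ccc(OCCC(O)(CC)CC)c(C)c2)n1CC`) gives 2290 nM, and the step between them is a 1.1-fold lower number from compound 1 to compound 2 (0.02 log units; within the scatter).

Compound 3 (`CCn1c(C(=O)NCC#N)ccc1C(CC)(CC)c1ccc(OCCC(O)(CC)CC)c(C)c1`) stands at > 50000 nM, which is a limit of the assay and not a number.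

Compound 4 (`CCn1c(C(=O)NCCN)ccc1C(CC)(CC)c1ccc(OCCC(O)(CC)CC)c(C)c1`) differs from compound 3 by aminomethyl in place of cyano on a saturated chain carbon bound to an amide-type nitrogen.

Going by the values given here, two measured steps bear on this change: an at least 20-fold higher number from compound 1 to compound 3 (1.31 log units; beyond the scatter), and an at least 21-fold higher number from compound 2 to compound 3 (1.33 log units; beyond the scatter). Both are large, and both arrive at cyano in this same place, whereas the present change removes it. A large step towards a lower number is therefore expected in this assay. Among the compounds with values here, no measured compound carries aminomethyl here, and the limit on compound 3 leaves the true size of the step open, so the range stays wide.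

The expected step is an at least 12-fold lower number from compound 3 to compound 4 (1.09 log units; beyond the scatter). The estimate for compound 4 is 4000 nM, with an expected range of 1200 nM to 20000 nM.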

Compound 4, half-maximal inhibitory concentration: 2940 nM
The estimate for compound 4 lay 1.4-fold (0.13 log units) above the measured number, within the range that was stated.
By their numbers in this assay, from the lowest: compounds 2, 1 and 4 (each within the scatter of the next). At a limit, above all of these: compound 3.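

In this assay, aminomethyl in place of cyano on a saturated chain carbon bound to an amide-type nitrogen is a large change (an at least 17-fold lower number from compound 3 to compound 4 (1.23 log units; beyond the scatter)). Going by these compounds alone, the plain amino end of compound 4 is not separated from the substituted ends of the earlier compounds, as amino in place of diethylamino (a 1.3-fold higher number from compound 2 to compound 4 (0.11 log units; within the scatter)) and amino in place of (dimethylamino)methyl (a 1.2-fold higher number from compound 1 to compound 4 (0.08 log units; within the scatter)) both stay within the scatter. Among these four compounds, then, all three with an amine at the chain end sit together, and the alkyl groups on that nitrogen make no readable difference.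

Going by these compounds, whether a hydroxyl, a carboxylic acid or a longer chain at this end would sit with the amines or with the nitrile stays open. The true size of the step from the nitrile also stays open, as compound 3 stands at a limit and not at a number: the limit of > 50000 nM in this assay, at which 1 of the 4 values shown sits.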